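Acetyl, sulfonyl and benzoyl on one nitrogen of a shared core

The source may report more compounds than this note shows. Statements on the series, on what has been measured and on what is new or still open speak of the compounds shown alone.

Compound 1 `CC(=O)Nc1ccc(Nc2ncnc3c2cnn3CC(=O)O)cc1` carries an acetyl group on a nitrogen on an aromatic ring. In a functional assay on cells (Homo sapiens) for inhibition, read by MTT assay, with a stated time of 72 h (on this read-out lower numbers stand for stronger inhibition and higher numbers for weaker inhibition), compound 1 gives only a limit, > 64 ug/mL. Compound 2 `O=C(O)Cn1ncc2c(Nc3ccc(NS(=O)(=O)c4ccc(Br)cc4)cc3)ncnc21` carries (4-bromophenyl)sulfonyl in place of that acetyl. In this assay compound 2 likewise gives only a limit, > 64 ug/mL. The step that the two limits leave unreadable from compound 1 to compound 2 cannot be sized, since (the limit of > 64 ug/mL in this assay, at which 2 of the 2 values shown sit). Compound 2 therefore stands at the limit with no number of its own. Compound 3 `O=C(O)Cn1ncc2c(Nc3ccc(NC(=O)c4ccccc4)cc3)ncnc21` differs from compound 2 in one place: benzoyl in place of (4-bromophenyl)sulfonyl on a nitrogen on an aromatic ring. Among the compounds with values here, the single measured step, the one just named, bears on this change but offers no size and no direction; the two limits show only that neither acetyl nor (4-bromophenyl)sulfonyl on this nitrogen gave a readable value. The expected step is a step that the limit leaves unreadable from compound 2 to compound 3, none beyond the scatter. Compound 3 is thus expected at 90 ug/mL, within 40 ug/mL to 250 ug/mL, and most likely reported again as a limit.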

Compound 3, half-maximal inhibitory concentration: > 100 ug/mL
Compound 3 was reported as a limit; the forecaster's own chance of this, stated with the estimate: 80%; middle value at least 1.1-fold (0.04 log units) from the limit.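

Within the data shown here, compound 3 gives only a limit in this assay, as do compound 1 and compound 2, so no step from compound 1 or compound 2 to compound 3 can be read. Open remains how acetyl, (4-bromophenyl)sulfonyl and benzoyl on this nitrogen compare in this assay.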